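Small steps so far, and a bigger group next

The source may report more compounds than this note shows. Statements on the series, on what has been measured and on what is new or still open speak of the compounds shown alone.

Compound 1 `N#Cc1c(O)nc(SCc2nc3ccccc3[nH]2)nc1-c1ccccc1`: 6.09 nM
Compound 2 `N#Cc1c(NN)nc(SCc2nc3ccccc3[nH]2)nc1-c1ccccc1`: 2.55 nM
Compound 3 `CNc1nc(SCc2nc3ccccc3[nH]2)nc(-c2ccccc2)c1C#N`: 3.7 nM

All three numbers come from a functional assay on RKOp27 cells (Homo sapiens) for cytotoxicity, read by MTT assay, with a stated time of 3 days; on this read-out higher numbers stand for weaker inhibition and lower numbers for stronger inhibition. Compound 3 stands second highest of the three numbers, but it lies within the usual scatter of both others, so it cannot really be ranked against either. Compound 4 `N#Cc1c(NNC(N)=S)nc(SCc2nc3ccccc3[nH]2)nc1-c1ccccc1` is the next to be measured. Its structural change from compound 3 is a group of 4 heavy atoms (1 carbon, 2 nitrogen, 1 sulfur; no ring) in place of one carbon atom, on a nitrogen on an aromatic ring.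

For the measured compounds named here, three measured steps bear on this change. The closest is a 1.5-fold higher number from compound 2 to compound 3 (0.16 log units; within the scatter), which swaps a group on the same nitrogen. The other two replace hydroxy with a nitrogen-linked group: a 1.6-fold lower number from compound 1 to compound 3 (0.22 log units; within the scatter), and a 2.4-fold lower number from compound 1 to compound 2 (0.38 log units; beyond the scatter), the only one of the three beyond the scatter, and only modestly so. Going by the values given here, every step so far is therefore small. None of them, however, involves a group as large as the one entering here, so the data give no firm direction and a wide range is warranted. The expected outcome is no shift beyond the scatter, with an estimated 1.1-fold higher number from compound 3 to compound 4 (0.03 log units; within the scatter). For compound 4 the estimated value is 4 nM, with an expected range of 1.5 nM to 11 nM.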

Compound 4, half-maximal inhibitory concentration: 3.2 nM
For compound 4 the middle estimate is 1.3-fold (0.10 log units) above the measured one; the range from low to high includes it.
By their numbers in this assay, from the lowest: compounds 2, 4, 3 and 1 (each within the scatter of the next, the first and the last beyond it).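

Replacing the methyl on this nitrogen on an aromatic ring with a group of 4 heavy atoms, carrying 2 hydrogen-bond donors and 1 hydrogen-bond acceptor, leaves the result in this assay within the scatter (a 1.2-fold lower number from compound 3 to compound 4 (0.06 log units; within the scatter)), so the larger group brings no measurable shift at this place. The other two comparisons agree: a group of 3 heavy atoms in place of a hydrogen atom on the amine nitrogen gives a 1.3-fold higher number from compound 2 to compound 4 (0.10 log units; within the scatter), and a group in place of one oxygen atom on the aromatic carbon gives a 1.9-fold lower number from compound 1 to compound 4 (0.28 log units; within the scatter), both also within the scatter. Nothing available explains why these numbers stay so close.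

The compounds shown leave open whether the same holds for other groups on this nitrogen, such as a longer alkyl chain, a carboxylic acid, or a group with oxygen in place of the sulfur. They also leave open how far a group larger than these, for example one carrying a phenyl ring, could go at this place before the number moves beyond the scatter.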